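Moving the Bromine from 4-Bromophenyl to 3-Bromophenyl

The source may hold more compounds than are shown below. What is called first, only, known or untested is meant among the compounds shown, and "the series" means these compounds.

In a functional assay on HL-60 cells (Homo sapiens) for antiproliferative activity, read by MTT assay, with a stated time of 72 h (on this read-out higher numbers stand for weaker inhibition and lower numbers for stronger inhibition), compound 2 (`NC1=NC2(CCSCC2)N(OCCCOc2ccc(Br)cc2)C(N)=N1`) gives 350 nM. This lies within the scatter of compound 1 (`CC(C)(C)c1ccc(OCCCON2C(N)=NC(N)=NC23CCSCC3)cc1`), which gives 280 nM. Compound 3 (`NC1=NC2(CCOCC2)N(OCCCOc2cc(Cl)c(Cl)cc2Cl)C(N)=N1`) gives 2360 nM, the highest number of the three and well clear of the value for compound 2.

The next compound to be measured is compound 4 (`NC1=NC2(CCSCC2)N(OCCCOc2cccc(Br)c2)C(N)=N1`). Its change is 3-bromophenyl in place of 4-bromophenyl on an oxygen on a saturated carbon, with 3-bromophenyl in place of 4-bromophenyl on an oxygen on a saturated carbon.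

For the measured compounds named here, one measured step bears on this change: a 1.3-fold higher number from compound 1 to compound 2 (0.10 log units; within the scatter), with bromo in place of tert-butyl on an aromatic carbon. That step exchanges one group for another, so the data hold no direct measure of moving the bromine. Going by the values given here, with only this small step as a guide, no shift beyond the scatter is expected in this assay, although the uncertainty is wide. The expected step is a 1.1-fold higher number from compound 2 to compound 4 (0.06 log units; within the scatter). For compound 4 the estimated value is 400 nM, within an expected range of 150 nM to 1100 nM.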

Compound 4, half-maximal inhibitory concentration: 200 nM
Compound 4: middle estimate off by 2.0-fold (0.30 log units), on the high side, within the range that was stated.
By their numbers in this assay, from the lowest: compounds 4, 1 and 2 (each within the scatter of the next); then compound 3.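

In this assay, for the compounds shown here, moving the bromine gives a 1.8-fold lower number from compound 2 to compound 4 (0.24 log units; within the scatter), and this is the first direct reading of the change: the earlier step exchanged one group for another, whereas this one keeps the same atoms, joined differently. On an oxygen on a saturated carbon, then, 4-bromophenyl and 3-bromophenyl cannot be told apart on the core of compound 2 in this assay. Nothing measured here offers an explanation for this result.

On these data alone, whether an amine or a carboxylic acid in place of the bromine would move the number beyond the scatter remains open. So does the effect of a longer chain joining the aromatic ring to the core, which these compounds do not test.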